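The compounds below may be only part of what the source reports. "The series", "measured", "known", "first", "only" and "open" are said of these compounds alone.

Of the compounds shown here, two of this set have been measured in a functional assay on DU-145 cells (Homo sapiens) for inhibition; a higher number here means a weaker inhibitor, a lower number a stronger inhibitor. Compound 1 `Oc1ccc(-c2cc(-c3ccc(F)cc3)cc(-c3ccccc3O)n2)cc1` gives > 50000 nM there, and that value is a limit of the assay rather than a number. Compound 2 `Oc1cccc(-c2cc(-c3ccc(OC(F)(F)F)cc3)cc(-c3ccccc3O)n2)c1` gives 21100 nM in this assay; this is the only number shown. The other value reported, that of compound 1, is a limit (the limit of > 50000 nM in this assay, at which 1 of the 2 values shown sits). Compound 3 `Oc1ccc(-c2cc(-c3ccc(OC(F)(F)F)cc3)cc(-c3ccccc3O)n2)cc1` has not yet been measured. It differs from compound 2 by 4-hydroxyphenyl in place of 3-hydroxyphenyl on an aromatic carbon, a change that rearranges the same atoms on the shared core. Compound 1 also carries a 4-hydroxyphenyl group, and in this assay compound 1 reaches a limit, > 50000 nM. The step from compound 2 to compound 3 is expected to weaken inhibition, by roughly a 1.9-fold higher number from compound 2 to compound 3 (0.28 log units; within the scatter). Compound 3 is estimated to give 40000 nM in this assay, with a likely range from 15000 nM to 100000 nM, and a real chance that only a limit is reported.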

Compound 3, half-maximal inhibitory concentration: > 50000 nM
Compound 3: no number, only a limit (the forecaster's own chance of this, stated with the estimate: 50%); middle value at least 1.2-fold (0.09 log units) from the limit.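

In this assay, placing 4-hydroxyphenyl instead of 3-hydroxyphenyl on the aromatic carbon next to the ring nitrogen gives an at least 2.3-fold higher number from compound 2 to compound 3 (0.37 log units; beyond the scatter), so inhibition at this position depends on where the hydroxyl sits on the ring, even though the atoms stay the same. Compound 3 gives > 50000 nM, which is a limit of the assay and not a number. The step from compound 1 to compound 3 cannot be read, and the compounds now gather at a single limit: the limit of > 50000 nM in this assay, at which 2 of the 3 values shown sit.

On these data alone, how far compound 1 and compound 3 lie past that limit stays open, and with it the size of the change from fluoro to trifluoromethoxy. Also open, as far as these compounds go, is how this position would respond if an amine or a carboxylic acid took the place of the hydroxyl on this ring.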